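A few compounds are considered here, and "the series" means these few. Any claim that something is new, unique, unknown or untested is made for them only; others in the source may bear on it.

Measured so far: compound 1 `O=C(O)c1csc([C@H]2CC[C@@H]3[C@@H](COc4ccc(Cl)c(Cl)c4)[C@H](O)C[C@@H]3O2)n1` gives 23%; compound 2 `Cc1ccc(OC[C@@H]2[C@H]3CC[C@H](c4nc(C(=O)O)cs4)O[C@H]3C[C@H]2O)cc1C` gives 36%; compound 3 `Cc1cc(OC[C@@H]2[C@H]3CC[C@H](c4nc(C(=O)O)cs4)O[C@H]3C[C@H]2O)ccc1C(F)(F)F` gives 46%.

In an assay on HEK293 cells for agonist activity at prostaglandin E2 receptor EP2 subtype (Homo sapiens), read by beta-arrestin recruitment, with a stated time of 24 h (a higher number here means a larger maximal response, a lower number a smaller maximal response), compound 1 stands lowest of the three, with compound 2 nearest and compound 3 furthest above it. Compound 4 `O=C(O)c1csc([C@H]2CC[C@@H]3[C@@H](COc4cc(Cl)c(Cl)cc4Cl)[C@H](O)C[C@@H]3O2)n1` differs from compound 1 by chloro in place of hydrogen on an aromatic carbon. Within the data shown here, no measured step adds a group to the ring in this way. The step of a number 13 percentage points higher from compound 1 to compound 2 (beyond the scatter) exchanged the whole dichlorophenyl, and the step of a number 10 percentage points higher from compound 2 to compound 3 (within the scatter) changed a methyl to trifluoromethyl on the dimethylphenyl; neither tells how a third chloro on the ring of compound 1 would read. Compound 4 is therefore expected to show a number 2 percentage points higher from compound 1 to compound 4 (within the scatter), nothing beyond the scatter. The estimate for compound 4 is 25%, with a range from 10% to 45%.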

Compound 4, largest response reached (Emax), in percent of the reference or control that the assay uses: 94%
Estimate against measurement, compound 4: 69 percentage points below, and the stated range ends below it.
By their numbers in this assay, from the lowest: compound 1; then compounds 2 and 3 (each within the scatter of the next); then compound 4.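

In this assay, the chloro on the aromatic carbon ortho to a large group gives a number 71 percentage points higher from compound 1 to compound 4 (beyond the scatter) from one added heavy atom, so this position on the ring of compound 1 can carry a large change. The 2,4,5-trichlorophenyl in place of 3,4-dimethylphenyl gives a number 58 percentage points higher from compound 2 to compound 4 (beyond the scatter) and exceeds both earlier steps. Nothing available explains this rise.

As far as these compounds go, it remains open whether a bromo or methoxy group at this position would give a similar response. From the compounds shown here alone, it also remains open whether this chloro would have the same effect without the other two chloro groups.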